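Nitro to carboxy: working notes on compound 3

The compounds below may be only part of what the source reports. "The series", "measured", "known", "first", "only" and "open" are said of these compounds alone.

For the measured compounds named here, in a functional assay on K562 cells (Homo sapiens) for antiproliferative activity (on this read-out lower numbers stand for stronger inhibition and higher numbers for weaker inhibition), compound 1 (`Nc1n[nH]c(N)c1/N=N/c1cccc([N+](=O)[O-])c1`) gives 79000 nM and holds the only numeric value so far. Compound 2 (`Nc1n[nH]c(N)c1/N=N/c1ccccc1O`) reads > 100000 nM and this is a limit of the assay, not a number. Compound 1 therefore has no numeric neighbour against which to rank it.

Compound 3 (`Nc1n[nH]c(N)c1/N=N/c1cccc(C(=O)O)c1`) carries carboxy in place of nitro on an aromatic carbon, with the rest of the core of compound 1 unchanged: carboxy in place of nitro on an aromatic carbon. Going by the values given here, no measured step between two compounds is available to calibrate this change. In this assay the estimated 1.2-fold higher number from compound 1 to compound 3 (0.08 log units; within the scatter) is expected to stay within the usual scatter, leaning if anything toward weaker inhibition. For compound 3 the estimated value is 95000 nM with an expected range from 40000 nM to 200000 nM and a limit in place of a number would be no surprise.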

Compound 3, half-maximal inhibitory concentration: > 100000 nM
Compound 3 ended at the assay's limit (the forecaster's own chance of this, stated with the estimate: 50%); middle value at least 1.0-fold (0.02 log units) from the limit.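

In this assay, carboxy in place of nitro on this aromatic carbon gives an at least 1.2-fold higher number from compound 1 to compound 3 (0.10 log units; that floor lies within the scatter), the only step shown so far that calibrates a change at this position. Compound 3 reads > 100000 nM, which is a limit of the assay and not a number. The step is therefore only a floor and its true size cannot be read, because the values in this series run into the same limit: the limit of > 100000 nM in this assay, at which 2 of the 3 values shown sit.

From the compounds shown here alone, whether any group on this aromatic carbon gives a number clearly lower than that of compound 1, at 79000 nM, remains open. An amine or a nitrile in place of nitro, on the unchanged core of compound 1, would bear directly on that question.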